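The source may hold more compounds than are shown below. What is called first, only, known or untested is meant among the compounds shown, and "the series" means these compounds.

Series notes. Compound 1 `Cc1ccc(N2C(=O)C/C(=C\c3cccc(C(=O)Nc4cccc(F)c4)c3)C2=O)cc1`, compound 2 `CCCCCN1C(=O)C/C(=C\c2cccc(C(=O)Nc3cccc(F)c3)c2)C1=O` and compound 3 `O=C(Nc1ccccc1)c1cccc(/C=C2\CC(=O)N(c3ccccc3)C2=O)c1` share one core and differ only in the group on an amide-type nitrogen in a ring or on the anilide side. In an ADME assay on NCM460 cells (Homo sapiens) for cytotoxicity, read by MTT assay, with a stated time of 72 h (a lower number here means a stronger inhibitor, a higher number a weaker inhibitor), compound 1 returns only a limit, > 100000 nM. Compound 2 likewise sits at a limit in this assay, > 100000 nM. Compound 3 also gives a limit in this assay, > 100000 nM. Among the compounds with values here, the single change with a pair of values, a step that the two limits leave unreadable from compound 1 to compound 2, therefore has no readable size, and the whole picture is the limit of > 100000 nM in this assay, at which 3 of the 3 values shown sit. Compound 4 `O=C(Nc1ccc(OC(F)F)cc1)c1cccc(/C=C2\CC(=O)N(c3ccccc3)C2=O)c1` differs from compound 3 by difluoromethoxy in place of hydrogen on an aromatic carbon. Within the data shown here, no measured step touches this change, and none of the measured steps has a readable size, so nothing in the set points to movement in either direction. The expected step that the limit leaves unreadable from compound 3 to compound 4 is accordingly nothing beyond the scatter, with a limit the most probable outcome. Compound 4 is estimated in this assay at 150000 nM, between 70000 nM and 400000 nM.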

Compound 4, half-maximal inhibitory concentration: > 100000 nM
Compound 4: no number, only a limit; the forecaster's own chance of this, stated with the estimate: 85%; the middle value lies beyond the limit too.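

In this assay, within the data shown here, compound 4 gives only a limit, > 100000 nM and so no step from compound 3 to compound 4 can be read. The compounds shown leave open whether any change on the shared core shifts the read-out at all, because all the values stand at one limit: the limit of > 100000 nM in this assay, at which 4 of the 4 values shown sit.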